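The source may hold more compounds than are shown below. What is called first, only, known or untested is meant among the compounds shown, and "the series" means these compounds.

Compound 1, `O=C1N(CCCCCCCOc2ccc(Cl)cc2)CCN1c1ccncc1`, is one of three measured compounds. In a functional assay on cells (Homo sapiens) for cytotoxicity (a higher number here means that more compound is tolerated, a lower number that less compound is tolerated), compound 1 gives > 25000 nM, which is a limit of the assay and not a number. Compound 2, `O=C1N(CCCCCCOc2c(Cl)cccc2Cl)CCN1c1ccncc1`, gives > 25000 nM in this assay, again a limit. Compound 3, `O=C1N(CCCCCCCOc2ccc(Cl)cc2)CCN1c1cccnc1`, gives > 25000 nM in this assay, also a limit.

Compound 3 therefore stands only at a limit, as do the other two: every value shown sits at the limit of > 25000 nM in this assay, at which 3 of the 3 values shown sit. Compound 4, `Cc1ccc(OCCCCCCN2CCN(c3cccnc3)C2=O)cc1`, differs from compound 3 by 4-methylphenoxy in place of (4-chlorophenoxy)methyl on a saturated chain carbon, six bonds along the chain from an amide-type nitrogen in a ring. Among the measured compounds shown here, two measured steps touch the same kind of change. The change at the same place along the chain, a step that the two limits leave unreadable from compound 1 to compound 2, is unreadable, since both ends of it are limits. The change on the amide-type nitrogen in the ring, a step that the two limits leave unreadable from compound 1 to compound 3, is unreadable for the same reason. Neither step gives a size or a direction, so no step beyond the scatter can be read into the move from compound 3 to compound 4 in this assay. The expectation is that compound 4 is likewise reported only as a limit, with a step that the limit leaves unreadable from compound 3 to compound 4 as the expected step. Compound 4 is accordingly estimated at 30000 nM, with a range from 12000 nM to 100000 nM.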

Compound 4, half-maximal cytotoxic concentration: > 25000 nM
Compound 4: a limit, no number; the forecaster's own chance of this, stated with the estimate: 85%; the middle value is on the limit's open side.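

In this assay compound 4 is reported only as a limit, as compound 3 is, so no step can be read between compound 3 and compound 4. All the compounds stand at the same limit: the limit of > 25000 nM in this assay, at which 4 of the 4 values shown sit. The compounds shown leave open how far each lies from that limit and whether any of these changes alters the tolerated concentration.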